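Taking the chain off the aromatic ring

A few compounds are considered here, and "the series" means these few. Any claim that something is new, unique, unknown or untested is made for them only; others in the source may bear on it.

Values measured in a functional assay on HCT-116 cells (Homo sapiens) for inhibition, read by MTT assay, with a stated time of 48 h (a higher number here means a weaker inhibitor, a lower number a stronger inhibitor), are these:
compound 1 (`COc1ccc(N(C)c2nc(C)nc3ccccc23)cc1OCCC[Se]C#N`) gives 852 nM
compound 2 (`COc1ccc(N(C)c2nc(C)nc3ccccc23)cc1OCC[Se]C#N`) gives 18 nM

Among the measured compounds shown here, compound 2 at 18 nM holds the lower of the two numbers so far. For the measured compounds named here, the only measured step (a 47-fold lower number from compound 1 to compound 2 (1.68 log units; beyond the scatter)) shortens the chain and lies beyond the scatter. Compound 3 (`COc1ccc(N(C)c2nc(C)nc3ccccc23)cc1[Se]C#N`) differs from compound 2 as follows: a group of 3 heavy atoms (1 carbon, 1 nitrogen, 1 selenium; no ring) in place of a group of 6 heavy atoms (3 carbon, 1 nitrogen, 1 oxygen, 1 selenium; no ring), on an aromatic carbon on an aromatic carbon, ortho to a methoxy group. The measured step bears on this change only in part, since the oxygen leaves along with the rest of the chain, and two compounds establish no trend. Its size (a 47-fold lower number from compound 1 to compound 2 (1.68 log units; beyond the scatter)) does show that a single change in this chain can move the number far. A clearly higher number is therefore expected in this assay, though with wide uncertainty. The expected step is a 6.7-fold higher number from compound 2 to compound 3 (0.82 log units; beyond the scatter) and is only a rough estimate. For compound 3 the estimated value is 120 nM with an expected range of 15 nM to 1000 nM around it.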

Compound 3, half-maximal inhibitory concentration: 34 nM
The estimate for compound 3 lay 3.5-fold (0.55 log units) above the measured number, within the range that was stated.
By their numbers in this assay, from the lowest: compounds 2 and 3 (each within the scatter of the next); then compound 1.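

In this assay, placing the group of 3 heavy atoms directly on the aromatic carbon, ortho to a methoxy group, removes the oxygen and the whole chain from compound 2, yet the change stays within the scatter (a 1.9-fold higher number from compound 2 to compound 3 (0.28 log units; within the scatter)). An oxygen-linked chain at this position is therefore not required for a number in this range, which the two chain compounds alone could not show. The other new step (a 25-fold lower number from compound 1 to compound 3 (1.40 log units; beyond the scatter)) lies beyond the scatter, so among the three compounds only compound 1 stands apart, and its number does not follow a simple progression with the size of the group: compound 2 and compound 3 cannot be separated despite the difference between them. No measurement available here explains this behaviour at the position.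

The compounds shown leave open how much of the number depends on the selenium, since all three carry it alongside the nitrile, and a thiocyanate at the same aromatic carbon would test this directly. Also open, as far as these compounds go, is whether a longer chain than that of compound 1 continues the rise, and whether an amine or a carboxylic acid at the chain end is tolerated.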